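The compounds below may be only part of what the source reports. "The series", "measured", "known", "first", "only" and "open" are said of these compounds alone.

Compound 1 `CC1(C)OC2O[C@@H](Cc3cn4ccccc4nc3=O)C(OCc3ccccc3)C2O1` was tested in a functional assay on A549 cells (Homo sapiens) for cytotoxicity, read by MTT assay, with a stated time of 24 h (on this read-out lower numbers stand for stronger inhibition and higher numbers for weaker inhibition), where compound 1 gives 199000 nM. Compound 2 `O=c1nc2ccc(Br)cn2cc1Cc1ccc(Cl)cc1` gives 105000 nM in this assay; of the two numbers compound 1 has the higher, though the gap to compound 2 is within the scatter. For compound 3 `O=c1nc2ccc(Br)cn2cc1Cc1ccccc1` this assay gives only a limit, > 1000000 nM, not a number. The difference between the core of compound 1 and the core of compound 3 is not broken down here. Compound 2 differs from compound 3 by chloro in place of hydrogen on an aromatic carbon; this produced an at least 9.5-fold lower number from compound 3 to compound 2 (0.97 log units; beyond the scatter), and the step is stated as a least value because of the limit of > 1000000 nM in this assay, at which 1 of the 3 values shown sits. Compound 4 `CC1(C)OC2O[C@@H](Cc3cn4cc(Cl)ccc4nc3=O)C(OCc3ccccc3)C2O1` is not yet measured; it differs from compound 1 by chloro in place of hydrogen on an aromatic carbon. This is the same kind of change, not the same: in compound 2 the chloro sits on a six-membered aromatic ring of carbon only, para to a large group, whereas in compound 4 it sits on a six-membered aromatic ring with one nitrogen, part of a fused or bridged system of two rings, two atoms from the ring nitrogen, meta to a fused ring and para to a fused ring. With the places differing, the earlier step is only a loose guide. The expected step for compound 4 is a 2.2-fold lower number from compound 1 to compound 4 (0.34 log units; beyond the scatter), smaller than the measured one. That expectation rests on compound 1 at 199000 nM together with an at least 9.5-fold lower number from compound 3 to compound 2 (0.97 log units; beyond the scatter). The estimate for compound 4 is 90000 nM, expected to fall between 30000 nM and 300000 nM.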

Compound 4, half-maximal inhibitory concentration: 182000 nM
Beside the measured number, compound 4's estimate is 2.0-fold (0.31 log units) below it; measured number inside the range.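

In this assay, chloro in place of hydrogen on an aromatic carbon gives a 1.1-fold lower number from compound 1 to compound 4 (0.04 log units; within the scatter), so on this core the change has no effect that can be told from the scatter. Set beside the earlier step, the same change did not carry over between the two cores: the same change on two cores in this assay, an at least 9.5-fold lower number (0.97 log units; beyond the scatter) from compound 3 to compound 2 and a 1.1-fold lower number (0.04 log units; within the scatter) from compound 1 to compound 4, at least 8.7-fold (0.94 log units) apart, beyond the scatter of two such steps

On these data alone, this does not show that the core alone sets the outcome, as the chloro also sits on a different kind of ring in each pair, and the full size of the earlier step stays open, with compound 3 resting on a limit, > 1000000 nM, not a number.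

The compounds shown leave open whether chloro at another place on the ring with one nitrogen would move the number for the core of compound 1. They also leave open whether a different group there, such as an amine or a carboxylic acid, would give a step beyond the scatter.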